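The source may hold more compounds than are shown below. What is called first, only, known or untested is meant among the compounds shown, and "the series" means these compounds.

Measured so far in a toxicity assay on B16-F10 cells (Mus musculus) for cytotoxicity, read by CCK-8 assay, with stated times of 16 h and 24 h; on this read-out higher numbers stand for weaker inhibition and lower numbers for stronger inhibition
Compound 1 `COc1ccc2c(c1)CCc1c(-c3ccccc3)c3n(c1-2)[B-](F)(F)[N+]1=C(c2ccc(OCC(=O)O)cc2)C(I)=C(c2ccccc2)C1=N3` gives 346 nM
Compound 2 `COc1ccc2c(c1)CCc1c(-c3ccccc3)c3n(c1-2)[B-](F)(F)[N+]1=C(c2ccc(OCC(=O)N[C@@H](CC(=O)O)C(=O)O)cc2)C(I)=C(c2ccccc2)C1=N3` gives 126 nM

Compound 2 at 126 nM holds the lower of the two numbers. Compound 3 `COc1ccc2c(c1)CCc1c(-c3ccccc3)c3n(c1-2)[B-](F)(F)[N+]1=C(c2ccc(OCC(=O)N[C@@H](CCC(=O)O)C(=O)O)cc2)C(I)=C(c2ccccc2)C1=N3` has carboxymethyl in place of carboxy on a saturated chain carbon, two bonds along the chain from an amide-type nitrogen and a carbonyl carbon. Read one bond further out, this is (1,3-dicarboxypropyl)amino for (1,2-dicarboxyethyl)amino. Among the measured compounds shown here, no measured step covers this exact change. The nearest is a 2.7-fold lower number from compound 1 to compound 2 (0.44 log units; beyond the scatter), a modest step that installed the (1,2-dicarboxyethyl)amino group in place of hydroxy. Going by these compounds, the present change only alters that group, so no step beyond the scatter is expected in this assay, and the direction remains open. For compound 3 the estimated value is 140 nM, with an expected range of 60 nM to 320 nM. The expected change is a 1.1-fold higher number from compound 2 to compound 3 (0.05 log units; within the scatter).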

Compound 3, half-maximal inhibitory concentration: 212 nM
For compound 3 the middle estimate is 1.5-fold (0.18 log units) below the measured one, and the stated range covers the measured number.
By their numbers in this assay, from the lowest: compounds 2, 3 and 1 (each within the scatter of the next, the first and the last beyond it).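

In this assay carboxymethyl in place of carboxy on this saturated chain carbon gives a 1.7-fold higher number from compound 2 to compound 3 (0.23 log units; within the scatter) and so does not separate the two compounds, even with the one extra carbon counted in the group. The (1,3-dicarboxypropyl)amino group in place of hydroxy on the carbonyl carbon gives a 1.6-fold lower number from compound 1 to compound 3 (0.21 log units; within the scatter) and, unlike the (1,2-dicarboxyethyl)amino group, stays within the scatter of the parent acid, so the longer group sits within reach of both neighbours and is cleanly separated from neither. Nothing shown here gives a reason for these numbers.

Going by these compounds, whether a longer chain ending in a carboxylic acid would move the number beyond the scatter remains open. So does the effect of an amine at this same carbon in place of the carboxy or carboxymethyl group.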